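The source may hold more compounds than are shown below. What is called first, only, known or untested is meant among the compounds shown, and "the series" means these compounds.

Compound 1 `Cc1ccc(/C=C/C(=O)Nc2ccc3nc(N4CCC(O)(C5CC5)CC4)nc(C)c3c2)cc1` — in a functional assay on CHO-K1 cells for antagonist activity at melanin-concentrating hormone receptor 1 (Homo sapiens), read by inositol phosphate accumulation, with stated times of 10 min and 45 min (on this read-out higher numbers stand for weaker inhibition and lower numbers for stronger inhibition), compound 1 gives 107 nM
Compound 2 `Cc1nc(N2CCC(O)CC2)nc2ccc(NC(=O)/C=C/c3ccc(Cl)cc3)cc12` — compound 2 gives 73 nM
Compound 3 `Cc1nc(NCCNC(=O)C2CC2)nc2ccc(NC(=O)/C=C/c3ccc(OC(F)(F)F)cc3)cc12` — compound 3 gives 23 nM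

Of the three measured compounds, compound 3 stands at the lowest number, which on this read-out means the strongest inhibition. The nearest value is that of compound 2, and the gap to it lies beyond the usual scatter; the gap to compound 1 is wider still. All three share the same core and a cinnamide-type side chain, and differ in the group carried on that core and in the substituent on the phenyl ring.

Compound 4 `Cc1nc(N2CCC(N3CCNC3=O)CC2)nc2ccc(NC(=O)/C=C/c3ccc(OC(F)(F)F)cc3)cc12` has not yet been measured. It keeps the trifluoromethoxy-bearing side of compound 3 and differs from it in one place: 4-(2-oxoimidazolidin-1-yl)piperidin-1-yl in place of (2-((cyclopropylcarbonyl)amino)ethyl)amino on an aromatic carbon. Going by the values given here, the new group is a piperidin-1-yl, as in compounds 1 and 2, which both give higher numbers than compound 3; yet those two also carry a different phenyl substituent, so no clean step for this change alone is available. A modest step toward a higher number, possibly within the scatter, is expected, as a 1.5-fold higher number from compound 3 to compound 4 (0.18 log units; within the scatter). Compound 4 is therefore estimated at 35 nM, with a range from 10 nM to 120 nM.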

Compound 4, half-maximal inhibitory concentration: 31 nM
The estimate for compound 4 lay 1.1-fold (0.05 log units) above the measured number, within the range that was stated.
By their numbers in this assay, from the lowest: compounds 3 and 4 (each within the scatter of the next); then compounds 2 and 1 (each within the scatter of the next).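

Going by these compounds alone, this is the first pair in the set that differs in one place only, with the trifluoromethoxy-bearing side chain held constant, so it is the first direct reading of a change on this aromatic carbon between two ring nitrogen atoms. In this assay, replacing the open (2-((cyclopropylcarbonyl)amino)ethyl)amino chain with the larger 4-(2-oxoimidazolidin-1-yl)piperidin-1-yl gives a 1.3-fold higher number from compound 3 to compound 4 (0.13 log units; within the scatter), so the two compounds cannot be told apart on this read-out, even though the group goes from 9 to 12 heavy atoms, from a three-membered ring to five- and six-membered rings, and from 2 hydrogen-bond donors to 1. Nothing measured here explains this result.

As far as these compounds go, it remains open how much depends on the 2-oxoimidazolidin-1-yl ring itself, which could be tested by a bare piperidin-1-yl or by a piperidin-1-yl carrying an amine or a carboxylic acid in its place. From the compounds shown here alone, it also remains open whether the same exchange would give a similar result with chlorine or methyl on the phenyl ring instead of trifluoromethoxy, since this single pair speaks only for the trifluoromethoxy series.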